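This account rests on a few compounds, and the source may have more. Where it says the series, first, only, none or still open, it means among the compounds named here.

Working notes on the series, all read in a functional assay on ECa-109 cells (Homo sapiens) for antiproliferative activity, read by MTT assay, with a stated time of 72 h; on this read-out higher numbers stand for weaker inhibition and lower numbers for stronger inhibition. Compound 1 `CCCSc1nc(N/N=C/c2cccc(Cl)c2)c2nnn(Cc3ccccc3)c2n1` gives only a limit of the assay, > 64000 nM. Compound 2 `CCCSc1nc(N/N=C/c2cccs2)c2nnn(Cc3ccccc3)c2n1` also gives only a limit, > 64000 nM. Compound 3 `CCCSc1nc(N/N=C/c2ccccc2F)c2nnn(Cc3ccccc3)c2n1` likewise stands only as a limit, > 64000 nM, so no number places it within the series.

Compound 4 `CCCSc1nc(N/N=C(\C)c2ccc(Br)cc2)c2nnn(Cc3ccccc3)c2n1` differs from compound 3 as follows: a group of 10 heavy atoms (8 carbon, 1 nitrogen, 1 bromine; one six-membered aromatic ring of carbon only) in place of a group of 9 heavy atoms (7 carbon, 1 nitrogen, 1 fluorine; one six-membered aromatic ring of carbon only), on a nitrogen on an aromatic ring. The entering group carries bromine where the leaving group carries fluorine.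

The measured steps that bear on this change are a step that the two limits leave unreadable from compound 1 to compound 2, a step that the two limits leave unreadable from compound 1 to compound 3 and a step that the two limits leave unreadable from compound 2 to compound 3. All three exchange the ring on the carbon with a double bond to nitrogen, and none has a readable size, so they give no direction.

Because the limit of > 64000 nM in this assay, at which 3 of the 3 values shown sit, covers compound 1, compound 2 and compound 3, a limit is again the expected outcome in this assay, with any number expected only close under it. The expected step is an at least 1.2-fold lower number from compound 3 to compound 4 (0.10 log units; that floor lies within the scatter), and this is an estimate only. For compound 4 the estimated value is 50000 nM, with an expected range of 12000 nM to 64000 nM.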

Compound 4, half-maximal inhibitory concentration: 4670 nM
Beside the measured number, compound 4's estimate is 11-fold (1.03 log units) above it; the whole stated range lies above it.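

Going by these compounds alone, exchanging the group on a nitrogen on an aromatic ring gives the first readable number in this assay, with an at least 13-fold lower number from compound 3 to compound 4 (1.13 log units; beyond the scatter), with an at least 13-fold lower number from compound 2 to compound 4 (1.13 log units; beyond the scatter) and with an at least 13-fold lower number from compound 1 to compound 4 (1.13 log units; beyond the scatter). Each of these steps has a limit at one end, so each gives only a floor, and the steps among compound 1, compound 2 and compound 3 still cannot be read. Compound 4 is the only compound shown that stands off the limit: the limit of > 64000 nM in this assay, at which 3 of the 4 values shown sit.

The compounds shown do not separate the bromine from the additional carbon of the entering group, so either could carry the step. Going by these compounds, whether the number holds with chlorine or an amine in place of the bromine, or with a longer chain in place of the propyl chain on sulfur, stays open.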